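The source may report more compounds than this note shows. Statements on the series, on what has been measured and on what is new or still open speak of the compounds shown alone.

Compound 1 `COC(=O)C1=C(C)NC(C)=C(C(=O)OC(C)(C)C)C1c1[nH]cnc1Cl`: 1860 nM
Compound 2 `COC(=O)C1=C(C)NC(C)=C(C(=O)OCc2ccccc2)C1c1[nH]cnc1Cl`: 93.3 nM

Of the compounds shown here, two sharing one core have been tested in an assay on isolated protein for inhibition of Voltage-dependent L-type calcium channel subunit alpha-1C (Cavia porcellus); on this read-out lower numbers stand for stronger inhibition and higher numbers for weaker inhibition. Compound 1 gives 1860 nM, and compound 2 gives 93.3 nM, which is the lower of the two numbers and therefore marks the stronger inhibition seen so far. Going by the values given here, the one measured step, a 20-fold lower number from compound 1 to compound 2 (1.30 log units; beyond the scatter), shows that exchanging the group on the ester oxygen can move the number a long way.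

Compound 3 `COC(=O)C1=C(C)NC(C)=C(C(=O)OCCc2ccccc2)C1c1[nH]cnc1Cl` differs from compound 2 in that same region: benzyl in place of phenyl on a saturated chain carbon bound to an oxygen next to a carbonyl group. The measured step concerned a different exchange at that oxygen, so it does not fix the size of this one; it only shows that this part of the molecule is sensitive. Among the compounds with values here, with no step that directly bears on lengthening the chain between the ester oxygen and the aromatic ring, the expectation for compound 3 in this assay is a number close to that of compound 2, with the estimated step of a 1.1-fold higher number from compound 2 to compound 3 (0.03 log units; within the scatter) lying within the usual scatter. Compound 3 is therefore estimated at 100 nM, with a likely range from 30 nM to 330 nM.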

Compound 3, half-maximal inhibitory concentration: 79.4 nM
The estimate for compound 3 lay 1.3-fold (0.10 log units) above the measured number; measured number inside the range.
By their numbers in this assay, from the lowest: compounds 3 and 2 (each within the scatter of the next); then compound 1.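

In this assay, the step of a 1.2-fold lower number from compound 2 to compound 3 (0.07 log units; within the scatter) shows that benzyl and phenethyl on this ester oxygen cannot be told apart, so moving the phenyl ring one chain unit further out along the ester chain keeps the number at the level of compound 2. Against tert-butyl in compound 1, the exchange for phenethyl gives a 23-fold lower number from compound 1 to compound 3 (1.37 log units; beyond the scatter) and lies beyond the scatter, so among the compounds shown the large drop is no longer tied to benzyl alone but is also seen with a second group that carries a phenyl ring. Nothing shown here explains why either group differs so much from tert-butyl.

Still open, going by these compounds, is how far this tolerance reaches, for example whether a longer chain such as phenylpropyl would keep the number this low. On these data alone, it is also open whether the phenyl ring itself is needed, which a plain hexyl chain or an amine at the end of the chain in its place would test.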